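The source may hold more compounds than are shown below. What is called first, only, known or untested is meant among the compounds shown, and "the series" means these compounds.

Compound 3 `NC(=O)c1ccc(-c2cnc(C(=O)CCCCCCc3ccccc3)o2)nc1` is measured in an assay (Rattus norvegicus) for inhibition of Fatty-acid amide hydrolase 1 (Homo sapiens) (on this read-out lower numbers stand for stronger inhibition and higher numbers for weaker inhibition), at 1.2 nM. Among the three compounds measured, compound 3 gives the second highest number: its nearest neighbour is compound 2 `Cc1ccnc(-c2cnc(C(=O)CCCCCCc3ccccc3)o2)c1`, which in this assay gives 0.6 nM, and the furthest is compound 1 `NC(=O)c1cccc(-c2cnc(C(=O)CCCCCCc3ccccc3)o2)c1`, which gives 6 nM. The steps observed so far all exchange the group on the same aromatic carbon of the shared core: a 10-fold lower number from compound 1 to compound 2 (1.00 log units; beyond the scatter), a 5.0-fold lower number from compound 1 to compound 3 (0.70 log units; beyond the scatter) and a 2.0-fold higher number from compound 2 to compound 3 (0.30 log units; within the scatter). Compound 4 `O=C(CCCCCCc1ccccc1)c1ncc(-c2nnn[nH]2)o1` has not yet been measured in this assay. It differs from compound 3 by 1H-tetrazol-5-yl in place of 5-carbamoylpyridin-2-yl on an aromatic carbon. Among the compounds with values here, each measured step replaced one six-membered aromatic group by another; no measured step replaced such a group by a five-membered ring with four hetero atoms, so the direct evidence is thin. Because the spread of the measured steps reached a 10-fold lower number from compound 1 to compound 2 (1.00 log units; beyond the scatter), a change of comparable size is plausible, and the expectation is for a higher number in this assay, estimated as a 17-fold higher number from compound 3 to compound 4 (1.22 log units; beyond the scatter). Compound 4 is therefore expected to give about 20 nM, within a range from 3 nM to 150 nM.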

Compound 4, inhibition constant: 63 nM
Beside the measured number, compound 4's estimate is 3.2-fold (0.50 log units) below it; measured number inside the range.
By their numbers in this assay, from the lowest: compounds 2 and 3 (each within the scatter of the next); then compound 1; then compound 4.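

In this assay, the exchange on this carbon, next to the ring oxygen, is no longer a modest one once the six-membered aromatic group gives way to 1H-tetrazol-5-yl: the result is a 53-fold higher number from compound 3 to compound 4 (1.72 log units; beyond the scatter) and a 110-fold higher number from compound 2 to compound 4 (2.02 log units; beyond the scatter), both larger than the widest earlier step, a 10-fold lower number from compound 1 to compound 2 (1.00 log units; beyond the scatter). Even against 3-carbamoylphenyl, the group with the highest number so far, the change gives an 11-fold higher number from compound 1 to compound 4 (1.02 log units; beyond the scatter), so 1H-tetrazol-5-yl falls behind all three six-membered groups and this position does not accept every aromatic group equally. Nothing available accounts for this loss.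

The compounds shown leave open whether a carboxylic acid or a 1-methyltetrazol-5-yl group on this carbon would lie nearer to compound 3 or to compound 4. They also leave open whether a shorter chain on the carbonyl would alter the size of these steps.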